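The source may hold more compounds than are shown below. What is called first, only, known or untested is meant among the compounds shown, and "the series" means these compounds.

Four compounds share one core and differ only in the side chain carried on the aniline part. Compound 1 `CN(C)C(=O)c1cc2cnc(Nc3ccc(C(=O)NCCCCCN=C=S)cc3)nc2n1C1CCCC1` gives 29.3% in a functional assay on A549 cells (Homo sapiens) for inhibition, read by CCK-8 assay, with a stated time of 72 h, tested at 1 uM; a higher number here means a stronger effect of the compound at the concentration tested, a lower number a weaker effect. Compound 2 `CN(C)C(=O)c1cc2cnc(Nc3ccc(C(=O)NCCCCCN=C=S)cc3F)nc2n1C1CCCC1` carries a fluoro in place of hydrogen on an aromatic carbon and gives -1.6%; that single change produced a number 30.9 percentage points lower from compound 1 to compound 2 (beyond the scatter). Compound 3 `CN(C)C(=O)c1cc2cnc(Nc3ccc(C(=O)NCCCN=C=S)cc3O)nc2n1C1CCCC1` gives 55.9%, the highest of the three numbers, standing beyond the scatter above compound 1 and further still above compound 2.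

Compound 4 `CN(C)C(=O)c1cc2cnc(Nc3ccc(C(=O)NCCCCCN=C=S)cc3O)nc2n1C1CCCC1` is obtained from compound 3 by one change: a group of 5 heavy atoms (3 carbon, 1 nitrogen, 1 sulfur; no ring) in place of a group of 3 heavy atoms (1 carbon, 1 nitrogen, 1 sulfur; no ring), on a saturated chain carbon, three bonds along the chain from an amide-type nitrogen. No measured pair differs only in this way, so nothing shown bears directly on it. Among the measured compounds shown here, the one step available, from compound 1 to compound 2, concerns the fluoro and says nothing about the chain. Compound 1 already carries the group of 5 heavy atoms and sits below compound 3, but it also lacks the hydroxyl of compound 3, so the two differences cannot be separated. For the measured compounds named here, the expectation is therefore only that compound 4 stays near compound 3, with a step of a number 10.9 percentage points lower from compound 3 to compound 4 (beyond the scatter) as the best guess and wide uncertainty. Compound 4 is estimated at 45%, within a range from 20% to 65%.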

Compound 4, a percentage reported as inhibition, at one concentration (the size of the read-out at that concentration, not a potency): 23.1%
The estimate for compound 4 lay 21.9 percentage points above the measured number; measured number inside the range.
By their numbers in this assay, from the lowest: compound 2; then compounds 4 and 1 (each within the scatter of the next); then compound 3.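

With the hydroxy held constant, a group of 5 heavy atoms in place of a group of 3 heavy atoms gives a number 32.8 percentage points lower from compound 3 to compound 4 (beyond the scatter) in this assay, so the chain change alone moves this read-out, a point that the comparison of compound 1 with compound 3 could not settle because those two differ in two places. With the group of 5 heavy atoms held constant, the aromatic carbon can now be read more fully: hydroxy in place of hydrogen gives a number 6.2 percentage points lower from compound 1 to compound 4 (within the scatter), whereas hydroxy in place of fluoro gives a number 24.7 percentage points higher from compound 2 to compound 4 (beyond the scatter), so among these three compounds only the fluoro stands apart. Nothing available explains either the chain effect or the fluoro effect.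

As far as these compounds go, the group of 3 heavy atoms appears here only together with the hydroxy, so it remains open whether hydrogen or fluoro on the aromatic carbon would give the same pattern with that shorter group. Also open, from the compounds shown here alone, is how a longer chain, or an amine in place of the sulfur-containing end of the chain, would fare in this assay.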